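The source may report more compounds than this note shows. Statements on the series, on what has been measured and on what is new or still open speak of the compounds shown alone.

Compound 3 `CCN(CC)C(=O)CN(c1ccc(C)cc1)S(=O)(=O)c1ccc(C#N)cc1` carries a 4-cyanophenyl group on its sulfonyl sulfur. In a functional assay on CHO cells for inhibition of Orexin/Hypocretin receptor type 1 (Homo sapiens), read by FLIPR and calcium flux (a lower number here means a stronger inhibitor, a higher number a weaker inhibitor), compound 3 gives > 10000 nM, which is a limit of the assay rather than a number. Compound 1 `CCN(CC)C(=O)CN(c1ccc(C)cc1)S(=O)(=O)c1cccc(Cl)c1` gives > 10000 nM in this assay, again a limit. Compound 2 `CCN(CC)C(=O)CN(c1ccc(C)cc1)S(=O)(=O)c1cccc(F)c1` gives > 10000 nM in this assay, also a limit. Because all three values sit at the limit of > 10000 nM in this assay, at which 3 of the 3 values shown sit, the steps a step that the two limits leave unreadable from compound 1 to compound 2, a step that the two limits leave unreadable from compound 1 to compound 3 and a step that the two limits leave unreadable from compound 2 to compound 3 cannot be read. Compound 4 `CCN(CC)C(=O)CN(c1ccc(C)cc1)S(=O)(=O)c1ccccc1C` differs from compound 3 by 2-methylphenyl in place of 4-cyanophenyl on a sulfonyl sulfur. Going by the values given here, no measured step shows how a change on the sulfonyl sulfur moves this assay, so the step that the limit leaves unreadable from compound 3 to compound 4 is expected only with little confidence. Compound 4 is therefore expected to give 15000 nM, within 3000 nM to 60000 nM.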

Compound 4, half-maximal inhibitory concentration: > 10000 nM
Compound 4: no number, only a limit; the forecaster's own chance of this, stated with the estimate: 85%; the middle value is on the limit's open side.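

No step between compound 4 and compound 1, compound 2 or compound 3 can be read, because their values give no size to compare: the limit of > 10000 nM in this assay, at which 4 of the 4 values shown sit.

The compounds shown leave open whether any group on the sulfonyl sulfur changes the result in this assay at all.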